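A few compounds are considered here, and "the series" means these few. Any claim that something is new, unique, unknown or untested is made for them only; others in the source may bear on it.

Measured so far:
- compound 1, `COc1ccc(C(=O)CCc2cccc(OC)c2OC)c(O)c1`: 92.7%
- compound 2, `COc1ccc(C(=O)CCc2ccc(OC)cc2OC)c(O)c1`: 87.4%
- compound 3, `COc1ccc(C(=O)CCc2ccc(OC)c(OC)c2)c(O)c1`: 75.2%

In an ADME assay on RAW264.7 cells (Mus musculus) for cytotoxicity, read by MTT assay, with a stated time of 24 h, tested at 5 ug/mL (a higher number here means a weaker effect of the compound at the concentration tested, a lower number a stronger effect), compound 3 stands lowest of the three numbers; compound 2 lies nearest, and compound 1 furthest, both beyond the scatter, so compound 3 shows the strongest effect among the three. No two of these compounds differ in only one place, so the measured numbers give no step to lean on. Compound 4, `COc1ccc(C(=O)CCc2ccc(OC)c(OC)c2OC)c(O)c1`, has not yet been tested; it differs from compound 3 by methoxy in place of hydrogen on an aromatic carbon. Among the measured compounds shown here, with no comparable step in hand, the expected step of a number 3.8 percentage points higher from compound 3 to compound 4 (within the scatter) is small, toward a slightly weaker effect, and not beyond the scatter. Compound 4 is therefore estimated at 79%, within a range from 62% to 95%.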

Compound 4, a percentage reported as activity, at one concentration (the size of the read-out at that concentration, not a potency): 94.8%
Estimate against measurement, compound 4: 15.8 percentage points below, within the range that was stated.
By their numbers in this assay, from the lowest: compound 3; then compounds 2, 1 and 4 (each within the scatter of the next).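

In this assay methoxy in place of hydrogen, ortho to a large group, gives a number 19.6 percentage points higher from compound 3 to compound 4 (beyond the scatter) and so moves toward a weaker effect. The same change at the other two places on this ring gives a number 7.4 percentage points higher from compound 2 to compound 4 (within the scatter) and a number 2.1 percentage points higher from compound 1 to compound 4 (within the scatter) and so stays inside the usual scatter, which leaves this the one place among those shown where the change counts. Nothing shown gives a reason for that. Still open, going by these compounds, is whether an amine or a carboxylic acid at this position would move the number as methoxy does.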